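This account rests on a few compounds, and the source may have more. Where it says the series, first, only, none or still open, it means among the compounds named here.

Among the measured compounds shown here, compound 1 `Oc1cccc(-c2cc(-c3ccco3)cc(-c3ccccc3O)n2)c1` and compound 2 `Oc1ccccc1-c1cc(-c2ccoc2)cc(-c2ccccc2O)n1` share a core and differ in two places at once, so no single step between them can be drawn. In an assay on isolated protein for inhibition of DNA topoisomerase 1 (Homo sapiens), with a stated time of 30 min, tested at 100 uM (a lower number here means a weaker effect, a higher number a stronger effect of the compound at the concentration tested), compound 1 gives 90.1%, whereas compound 2 gives 1%, the lowest of the two numbers and far beyond the scatter from compound 1. Compound 3 `Oc1cccc(-c2cc(-c3ccoc3)cc(-c3ccccc3O)n2)c1` has not yet been measured. It arises from compound 2 by one change, (3-hydroxyphenyl in place of 2-hydroxyphenyl on an aromatic carbon), which gives compound 3 the same 3-hydroxyphenyl group that compound 1 carries. Because compound 1 reaches 90.1% while compound 2 sits at 1%, a large rise is expected, though the two compounds also differ in the furan group and the data cannot separate the two contributions. The step from compound 2 to compound 3 is estimated as a number 54 percentage points higher from compound 2 to compound 3 (beyond the scatter). For compound 3 the expected value in this assay is 55%, within 10% to 92%.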

Compound 3, a percentage reported as inhibition, at one concentration (the size of the read-out at that concentration, not a potency): 29.5%
For compound 3 the middle estimate is 25.5 percentage points above the measured one, within the range that was stated.
By their numbers in this assay, from the lowest: compound 2; then compound 3; then compound 1.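

The two single steps now separate what compound 1 and compound 2 could not show alone. In this assay, 3-hydroxyphenyl in place of 2-hydroxyphenyl gives a number 28.5 percentage points higher from compound 2 to compound 3 (beyond the scatter), a modest step, so the placement of the hydroxyl on this aryl group matters even with the furan-3-yl group held constant. Furan-3-yl in place of furan-2-yl gives a number 60.6 percentage points lower from compound 1 to compound 3 (beyond the scatter), a large step, so with 3-hydroxyphenyl held constant, the point of attachment of the furan carries much of the gap between compound 1 and compound 2.

Going by these compounds, whether an amine or a carboxylic acid in place of the hydroxyl, or a thiophene in place of the furan, would keep the value of compound 1 remains open. Nothing at hand explains why either change has the effect it does.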